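The source may report more compounds than this note shows. Statements on the series, on what has been measured and on what is new or still open speak of the compounds shown alone.

The measured compounds:

Compound 1, `Nc1ccc2oc(-c3ccc(F)cc3)cc(=O)c2c1`: in an ADME assay on THP-1 cells (Homo sapiens) for cytotoxicity, read by flow cytometry and propidium iodide staining, with a stated time of 72 h (on this read-out lower numbers stand for stronger inhibition and higher numbers for weaker inhibition), compound 1 gives 10000 nM.
Compound 2, `Nc1ccc2oc(-c3ccc(C(F)(F)F)cc3)cc(=O)c2c1`: compound 2 gives 1900 nM.
Compound 3, `COc1c(-c2ccc(F)cc2)oc2ccc(NC(C)=O)cc2c1=O`: for compound 3 the result is a limit of the assay, > 125000 nM.

Compound 1 and compound 2 share a core and differ in one place: trifluoromethyl in place of fluoro on an aromatic carbon. That change produced a 5.3-fold lower number from compound 1 to compound 2 (0.72 log units; beyond the scatter). Compound 3 carries a different core; how the core of compound 3 differs from that of compound 1 is not broken down here. Compound 3 stands at a limit, and the line the limit of > 125000 nM in this assay, at which 1 of the 3 values shown sits, marks that its value is only a bound, not a number.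

Compound 4, `COc1c(-c2ccc(C(F)(F)F)cc2)oc2ccc(NC(C)=O)cc2c1=O`, has not yet been measured in this assay. It stands to compound 3 as compound 2 stands to compound 1, the change being (trifluoromethyl in place of fluoro on an aromatic carbon), the same change at the same kind of place. Within the data shown here, since the only measured instance of this change, from compound 1 to compound 2, moved the number down, compound 4 is expected to show an at least 2.5-fold lower number from compound 3 to compound 4 (0.39 log units; beyond the scatter) from the bound of compound 3, an expectation that rests on that single step alone and on a starting point that is itself only a limit. Compound 4 is therefore estimated at 50000 nM, with a range from 15000 nM to 250000 nM, and a fair chance that the assay again returns only a limit for compound 4.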

Compound 4, half-maximal inhibitory concentration: > 125000 nM
Compound 4: a limit, no number (the forecaster's own chance of this, stated with the estimate: 50%); middle value at least 2.5-fold (0.39 log units) away from the limit.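

In this assay compound 4 gives > 125000 nM, which is a limit of the assay and not a number. Compound 3 gives > 125000 nM, also a limit. The step between these two compounds therefore cannot be read: the limit of > 125000 nM in this assay, at which 2 of the 4 values shown sit. The compounds shown leave open whether trifluoromethyl in place of fluoro on an aromatic carbon moves the number at all on the core of compound 3.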